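A few compounds are considered here, and "the series" means these few. Any claim that something is new, unique, unknown or untested is made for them only; others in the source may bear on it.

Three compounds were measured in a functional assay on PC-3 cells (Homo sapiens) for antiproliferative activity, read by MTT assay, tested at 5 uM; a lower number here means a weaker effect, a higher number a stronger effect of the compound at the concentration tested:

Compound 1 `COc1cc(C(=O)N/N=C/c2ccc(F)c(F)c2)cc(OC)c1OC`: 43.7%
Compound 2 `COc1cc(C(=O)N/N=C/c2ccc(C(F)(F)F)cc2)cc(OC)c1OC`: 61.6%
Compound 3 `COc1ccc(OC)c(/C=N/NC(=O)c2cc(OC)c(OC)c(OC)c2)c1`: 51.7%

Of these three numbers, that of compound 1 is the lowest, but compound 3 sits within the usual scatter of it; only compound 2 stands beyond that scatter. Compound 4 `COc1cc(C(=O)N/N=C/c2c(Cl)cccc2Cl)cc(OC)c1OC` differs from compound 1 in one place: 2,6-dichlorophenyl in place of 3,4-difluorophenyl on a carbon with a double bond to nitrogen. Going by the values given here, no pair of measured compounds isolates this change, so nothing shows how the move from one halogenated ring to another acts in this assay. The expectation is therefore a step from compound 1 to compound 4 of about a number 6.3 percentage points higher from compound 1 to compound 4 (within the scatter), not beyond the scatter in either direction. Compound 4 is thus estimated at 50%, within a range from 30% to 68%.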

Compound 4, a percentage reported as inhibition, at one concentration (the size of the read-out at that concentration, not a potency): 52.1%
Beside the measured number, compound 4's estimate is 2.1 percentage points below it; the range from low to high includes it.
By their numbers in this assay, from the lowest: compounds 1, 3, 4 and 2 (each within the scatter of the next, the first and the last beyond it).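

In this assay, going by these compounds alone, placing 2,6-dichlorophenyl in place of 3,4-difluorophenyl on a carbon with a double bond to nitrogen gives a number 8.4 percentage points higher from compound 1 to compound 4 (within the scatter) and so offers the first direct reading at this position. For this pair, the exchange of one dihalogenated ring for another does not move the read-out beyond the scatter. No available evidence explains this result.

The pair changes both the halogen and its places on the ring, so the contribution of each remains unresolved. From the compounds shown here alone, whether an amine or a carboxylic acid on this ring would be accepted also remains open.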